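The source may hold more compounds than are shown below. What is called first, only, known or untested is meant among the compounds shown, and "the series" means these compounds.

Measured so far:
- compound 1, `CCOC(=O)c1ccc(NC(=O)N2CC2C#N)cc1`: 9700 nM
- compound 2, `N#CC1CN1C(=O)NCc1ccccc1`: 3800 nM

Both compounds share a core that carries a nitrile on a small three-membered ring, joined through a urea to an aromatic portion. In a functional assay on L1210 cells (Mus musculus) for inhibition, read by MTT assay (a higher number here means a weaker inhibitor, a lower number a stronger inhibitor), compound 1 gives 9700 nM, and this is the higher of the two numbers: compound 2 gives a lower value in this assay, a gap that lies beyond the usual scatter of repeat measurements. Compound 1 is therefore the weaker inhibitor of the pair.

The next compound, compound 3, `N#CC1CN1C(=O)Nc1ccc(S(N)(=O)=O)cc1`, is not yet measured. It keeps the core of compound 1 and changes one group on the aromatic ring: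
sulfamoyl in place of ethoxycarbonyl on an aromatic carbon
Among the measured compounds shown here, no step between two measured compounds of this kind is available, so the effect of trading an ethoxycarbonyl for a sulfamoyl at this position cannot be read from the data. The change is expected to shift this assay only modestly, most likely within or close to the scatter, as a 1.2-fold lower number from compound 1 to compound 3 (0.08 log units; within the scatter). For compound 3 the expected value in this assay is 8000 nM, with a range from 3000 nM to 25000 nM.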

Compound 3, half-maximal inhibitory concentration: > 38000 nM
Compound 3 gave a limit, no number (the forecaster's own chance of this, stated with the estimate: 15%); middle value at least 4.7-fold (0.67 log units) from the limit.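

In this assay compound 3 gives > 38000 nM, which is a limit of the assay and not a number. Among the compounds shown here, putting sulfamoyl in place of ethoxycarbonyl on the aromatic carbon gives an at least 3.9-fold higher number from compound 1 to compound 3 (0.59 log units; beyond the scatter), so compound 3 is the weaker inhibitor, and this is the first direct sign that the group at this position matters in this cell assay. Only a lower bound on the size of the step can be read, and it rests on a single swap: the limit of > 38000 nM in this assay, at which 1 of the 3 values shown sits.

The compounds shown leave open whether the loss comes from bringing in sulfamoyl or from giving up ethoxycarbonyl, since one swap changes both at once. A carboxylic acid, an amine or a simple methyl group at the same place on the aromatic ring, with the rest of compound 1 unchanged, would help show which kinds of group this position tolerates and whether the ester of compound 1 has any special role.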